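The compounds below may be only part of what the source reports. "The series", "measured", "known", "first", "only" and "open" are said of these compounds alone.

Working notes on the series. The compounds share one core and differ only in the aryl group on an aromatic nitrogen. Compound 1 `Cc1ccccc1-n1cc(-c2ccc(NS(=O)(=O)c3c[nH]c(=O)[nH]c3=O)cc2)nn1` gives 3130 nM in a functional assay on A549 cells (Homo sapiens) for antiproliferative activity, read by MTT assay, with a stated time of 24 h; on this read-out lower numbers stand for stronger inhibition and higher numbers for weaker inhibition. Compound 2 `Cc1cccc(-n2cc(-c3ccc(NS(=O)(=O)c4c[nH]c(=O)[nH]c4=O)cc3)nn2)c1` gives 6960 nM in this assay, and compound 3 `Cc1ccc(-n2cc(-c3ccc(NS(=O)(=O)c4c[nH]c(=O)[nH]c4=O)cc3)nn2)cc1` gives 5560 nM in this assay. Compound 3 stands second highest of the three numbers, within the scatter of both others, as a 1.3-fold lower number from compound 2 to compound 3 (0.10 log units; within the scatter) and a 1.8-fold higher number from compound 1 to compound 3 (0.25 log units; within the scatter) show. Among the measured compounds shown here, the single step beyond the scatter is a 2.2-fold higher number from compound 1 to compound 2 (0.35 log units; beyond the scatter).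

Compound 4 `O=c1[nH]cc(S(=O)(=O)Nc2ccc(-c3cn(-c4ccccc4F)nn3)cc2)c(=O)[nH]1` is not yet measured; its change from compound 3 is 2-fluorophenyl in place of 4-methylphenyl on an aromatic nitrogen. For the measured compounds named here, no measured step swaps methyl for fluorine, so only the change of place bears on it: the steps of a 2.2-fold higher number from compound 1 to compound 2 (0.35 log units; beyond the scatter) and a 1.8-fold higher number from compound 1 to compound 3 (0.25 log units; within the scatter) both run toward higher numbers away from 2-methylphenyl, though only the first lies beyond the scatter. A modest lowering in this assay is therefore expected, probably within the scatter. Compound 4 is estimated at 3800 nM, with a range of 1600 nM to 9000 nM. The expected step is a 1.5-fold lower number from compound 3 to compound 4 (0.17 log units; within the scatter).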

Compound 4, half-maximal inhibitory concentration: 5960 nM
Compound 4: the middle estimate sits 1.6-fold (0.20 log units) below what was measured, and the stated range covers the measured number.
By their numbers in this assay, from the lowest: compounds 1, 3, 4 and 2 (each within the scatter of the next, the first and the last beyond it).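

Fluoro in place of methyl, with 2-methylphenyl becoming 2-fluorophenyl, gives a 1.9-fold higher number from compound 1 to compound 4 (0.28 log units; within the scatter), the first direct reading of this swap on the aryl group. In this assay, among the compounds shown here, 2-fluorophenyl also cannot be told apart from either of the other two aryl groups, with a 1.1-fold higher number from compound 3 to compound 4 (0.03 log units; within the scatter) and a 1.2-fold lower number from compound 2 to compound 4 (0.07 log units; within the scatter), so every step that touches compound 4 stays inside the scatter and only the step between compound 1 and compound 2 remains beyond it. No measurement at hand offers an explanation for these readings.

Open, from the compounds shown here alone, is whether 3-fluorophenyl or 4-fluorophenyl would read like their methyl counterparts. Also open, going by these compounds, is whether a carboxylic acid or an amine on this aryl group, or a longer alkyl chain in its place on the aromatic nitrogen, would move the number beyond the scatter.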